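Swapping a Branched Ester for a Fluorinated Aromatic One

The compounds below may be only part of what the source reports. "The series", "measured", "known", "first", "only" and "open" are said of these compounds alone.

Three measured compounds share one core and differ only in the ester group attached to it. Compound 1 `CCCCC(=O)O[C@H]1C[C@@H](C)C=C2C=C[C@H](C)[C@H](CC[C@@H]3C[C@@H](O)CC(=O)O3)C21` gives 8.7 nM in an assay for inhibition of 3-hydroxy-3-methylglutaryl-coenzyme A reductase (Rattus norvegicus); on this read-out lower numbers stand for stronger inhibition and higher numbers for weaker inhibition. Compound 2 `CC(CC(=O)O[C@H]1C[C@@H](C)C=C2C=C[C@H](C)[C@H](CC[C@@H]3C[C@@H](O)CC(=O)O3)C21)C(F)(F)F` gives 3.5 nM in this assay, and compound 3 `CCCC(CC)(CC)C(=O)O[C@H]1C[C@@H](C)C=C2C=C[C@H](C)[C@H](CC[C@@H]3C[C@@H](O)CC(=O)O3)C21` gives 1.9 nM. Compound 3 thus carries the lowest of the three numbers: one change produced a 4.6-fold lower number from compound 1 to compound 3 (0.66 log units; beyond the scatter), whereas the other produced a 1.8-fold lower number from compound 2 to compound 3 (0.27 log units; within the scatter), so compound 2 and compound 3 cannot be told apart on these figures. Compound 4 `C[C@H]1C=C2C=C[C@H](C)[C@H](CC[C@@H]3C[C@@H](O)CC(=O)O3)C2[C@@H](OC(=O)c2ccc(F)cc2)C1` has not been measured; it differs from compound 3 by 4-fluorophenyl in place of 1,1-diethylbutyl on a carbonyl carbon. Among the measured compounds shown here, no measured step puts an aromatic group at this position, so nothing bears on the change directly. For the measured compounds named here, the steps of a 2.5-fold lower number from compound 1 to compound 2 (0.40 log units; beyond the scatter) and a 4.6-fold lower number from compound 1 to compound 3 (0.66 log units; beyond the scatter) show only that altering the ester group shifts the number by modest amounts. A modest step in either direction, or none beyond the scatter, is therefore plausible, and a slight rise is expected, a 2.1-fold higher number from compound 3 to compound 4 (0.32 log units; beyond the scatter). Compound 4 is expected to give 4 nM, within a range from 1.5 nM to 11 nM.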

Compound 4, half-maximal inhibitory concentration: 37 nM
Compound 4: the middle estimate sits 9.3-fold (0.97 log units) below what was measured; the measured number lies above the stated range.
By their numbers in this assay, from the lowest: compounds 3 and 2 (each within the scatter of the next); then compound 1; then compound 4.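

In this assay, the ester position proves far less forgiving than the three chain-bearing compounds suggested: they differ by modest steps at most, whereas putting 4-fluorophenyl on the carbonyl carbon gives a 19-fold higher number from compound 3 to compound 4 (1.29 log units; beyond the scatter) and an 11-fold higher number from compound 2 to compound 4 (1.02 log units; beyond the scatter), both large. Even the plain butyl group does better than the aromatic group, with a 4.3-fold higher number from compound 1 to compound 4 (0.63 log units; beyond the scatter), so compound 4 carries the highest number of the four, and the only aromatic ester shown is also the weakest inhibitor here. Nothing available explains this difference.

The compounds shown leave open whether the higher number goes with the aromatic ring itself or with its fluorine. A plain phenyl group and a cyclohexyl group on the same carbonyl carbon would help to separate these two possibilities.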